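Methyl on the pyrazole: a repeated step in lipophilicity

The compounds below may be only part of what the source reports. "The series", "measured", "known", "first", "only" and "open" are said of these compounds alone.

Compound 1 `COCc1ccc(-c2ccc3nnc(C(N)=O)c(N[C@@H](C)c4ccn(C)n4)c3c2)cn1` gives 3 in a physicochemical assay for lipophilicity, using the shake flask method, measured as octanol-water partition, with a stated time of 30 min, at pH 7.4; a lower number here means a more polar compound, a higher number a more lipophilic compound. Compound 2 `COCc1ccc(-c2ccc3nnc(C(N)=O)c(N[C@@H](C)c4nn(C)cc4C)c3c2)cn1` differs from it by methyl in place of hydrogen on an aromatic carbon; in this assay compound 2 gives 2.8, and the step is a number 0.20 log units lower from compound 1 to compound 2 (within the scatter). Compound 3 `C[C@H](Nc1c(C(N)=O)nnc2ccc(-c3ccc(OCCCN(C)C)nc3)cc12)c1ccn(C)n1` carries a different core, the difference being (3-(dimethylamino)propoxy in place of methoxymethyl on an aromatic carbon); in this assay compound 3 gives 1.7, a step of a number 1.30 log units lower from compound 1 to compound 3 (beyond the scatter). Compound 4 `Cc1cn(C)nc1[C@H](C)Nc1c(C(N)=O)nnc2ccc(-c3ccc(OCCCN(C)C)nc3)cc12` is not yet measured and differs from compound 3 by methyl in place of hydrogen on an aromatic carbon, the same change as from compound 1 to compound 2, at a place described in the same words. The step is expected to be about a number 0.10 log units lower from compound 3 to compound 4 (within the scatter), resting on the earlier step of a number 0.20 log units lower from compound 1 to compound 2 (within the scatter), which lay within the scatter. Compound 4 is therefore estimated at 1.6, between 1.2 and 2.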

Compound 4, distribution coefficient: 2.1
Estimate against measurement, compound 4: 0.50 log units below; measured number outside the range, above it.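

In this assay, methyl in place of hydrogen on the pyrazole gives a number 0.40 log units higher from compound 3 to compound 4 (beyond the scatter), whereas on the core of compound 1 the same change gave a number 0.20 log units lower from compound 1 to compound 2 (within the scatter), so it did not carry across as a fixed increment. The other change, 3-(dimethylamino)propoxy in place of methoxymethyl, keeps its direction with the added methyl present, at a number 0.70 log units lower from compound 2 to compound 4 (beyond the scatter) against a number 1.30 log units lower from compound 1 to compound 3 (beyond the scatter). These two pairs set no rule for other cores, and nothing measured here accounts for the difference between them.

Still open, from the compounds shown here alone, is how ethyl in place of that methyl would behave on either core. Going by these compounds, it is also open whether morpholine in place of the dimethylamino group would change the size of the methyl step.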